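The compounds below may be only part of what the source reports. "The series", "measured", "known", "first", "only" and "open" are said of these compounds alone.

Measured compounds:
- compound 1, `Cc1ccc(NC2=CC(=O)c3c(nc4n3[C@H]3OC[C@@H](O)[C@H]3OC4)C2=O)cc1`, > 4000 nM
- compound 2, `O=C1C=C(Nc2cccc(F)c2)C(=O)c2c1nc1n2[C@H]2OC[C@@H](O)[C@H]2OC1`, 7030 nM

Of the compounds shown here, two sharing one core have been tested in a functional assay on ECa-109 cells for inhibition, with ECa-109 cell line (Homo sapiens) as the target, read by sulforhodamine B assay; on this read-out lower numbers stand for stronger inhibition and higher numbers for weaker inhibition. Compound 1 gives > 4000 nM, which is a limit of the assay rather than a number. Within the data shown here, compound 2 gives 7030 nM in this assay, and it is the only actual number available. Among the measured compounds shown here, there is therefore no measured step to compare against. For the measured compounds named here, the one piece of evidence on the measured values is the limit of > 4000 nM in this assay, at which 1 of the 2 values shown sits.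

Compound 3, `Cc1ccc(NC2=CC(=O)c3nc4n(c3C2=O)[C@H]2OC[C@@H](O)[C@H]2OC4)cc1`, has not yet been measured. It differs from compound 2 in one place: 4-methylphenyl in place of 3-fluorophenyl on an amine nitrogen. Going by the values given here, since no step between measured compounds exists, the size of this change can only be guessed. The shared core of compound 2 carries weak inhibition, and swapping one small aromatic group for another of the same size is expected to shift the result little, if at all, beyond the scatter. Compound 3 is therefore expected to give about 8000 nM in this assay, between 3000 nM and 25000 nM, a step of a 1.1-fold higher number from compound 2 to compound 3 (0.06 log units; within the scatter).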

Compound 3, half-maximal inhibitory concentration: 3480 nM
Beside the measured number, compound 3's estimate is 2.3-fold (0.36 log units) above it; low and high end bracket the measured number.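

On this assay, the amine nitrogen now has its first measured step: 4-methylphenyl in place of 3-fluorophenyl gives a 2.0-fold lower number from compound 2 to compound 3 (0.31 log units; beyond the scatter). The group on this nitrogen therefore matters to the read-out, since exchanging two groups with the same heavy-atom count, each a single all-carbon aromatic ring, moves the number beyond the usual scatter, although the step is only modest. The change alters two things at once, replacing fluorine with methyl and a 3-substituted ring with a 4-substituted one, and nothing measured here explains the step.

Which of those two alterations accounts for the step stays open, and a 3-methylphenyl or a 4-fluorophenyl group on the same amine nitrogen would separate them. As far as these compounds go, it is also open how far this position can move the number on the shared core, for example with a pyridine ring in place of the phenyl ring or with a carboxylic acid on the phenyl ring.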